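The compounds below may be only part of what the source reports. "The series", "measured", "known", "first", "only" and "open" are said of these compounds alone.

Compound 2 `COc1ccc(-c2nn(-c3ccccc3)cc2C(=O)/C=C\Nc2ccc(F)cc2)cc1` is the reference point. In a functional assay on HT-29 cells (Homo sapiens) for antiproliferative activity, read by MTT assay, with a stated time of 48 h (a lower number here means a stronger inhibitor, a higher number a weaker inhibitor), compound 2 gives 7650 nM, the only actual number among the results shown. Compound 1 `O=C(/C=C\Nc1ccc(C(F)(F)F)cc1)c1cn(-c2ccccc2)nc1-c1ccc(Cl)cc1` is reported in this assay only as a limit, > 50000 nM, and not as a number. That outcome is summarised as the limit of > 50000 nM in this assay, at which 1 of the 2 values shown sits. Compound 1 and compound 2 differ in more than one place, so their two results can be set side by side but not read as a single step. Compound 3 `COc1ccc(-c2nn(-c3ccccc3)cc2C(=O)/C=C\Nc2ccc(C(F)(F)F)cc2)cc1` has not yet been measured. It differs from compound 2 in one place: trifluoromethyl in place of fluoro on an aromatic carbon. For the measured compounds named here, no measured pair isolates this change. Compound 1 carries the same trifluoromethyl-bearing anilino group, and its result is a limit. For compound 3 a weakening step is expected in this assay, a 2.6-fold higher number from compound 2 to compound 3 (0.42 log units; beyond the scatter), with a real chance of a limit only. Compound 3 is expected to give 20000 nM, within 6000 nM to 60000 nM.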

Compound 3, half-maximal inhibitory concentration: 9870 nM
Estimate against measurement, compound 3: 2.0-fold (0.31 log units) above; the range from low to high includes it.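

In this assay, trifluoromethyl in place of fluoro on an aromatic carbon gives a 1.3-fold higher number from compound 2 to compound 3 (0.11 log units; within the scatter), so compound 2 and compound 3 cannot be told apart and this position accepts the larger group. Trifluoromethyl on this ring therefore does not by itself go with a weak result, since keeping it while placing methoxy where chloro stood gives an at least 5.0-fold lower number from compound 1 to compound 3 (0.70 log units; beyond the scatter). The true size of that second step stays open, since compound 1 is reported only as a limit: the limit of > 50000 nM in this assay, at which 1 of the 3 values shown sits.

The compounds shown do not say how a nitrile or an amine at this aromatic carbon would read. Nor do they say whether methoxy in place of chloro gives a similar step when fluoro replaces trifluoromethyl.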